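The source may report more compounds than this note shows. Statements on the series, on what has been measured and on what is new or still open speak of the compounds shown alone.

Measured in a functional assay on PC-3 cells (Homo sapiens) for inhibition, read by MTT assay, with a stated time of 48 h; a lower number here means a stronger inhibitor, a higher number a weaker inhibitor:
- compound 1 `COc1ccc(-c2coc3cc(OCCCSC(=S)N4CCN(C)CC4)ccc3c2=O)cc1`: 2210 nM
- compound 2 `CCN1CCN(C(=S)SCCCOc2ccc3c(=O)c(-c4ccc(OC)cc4)coc3c2)CC1`: 7080 nM

Compound 2, at 7080 nM, holds the higher of the two numbers and is the weaker inhibitor of the pair. Compound 3 `COc1ccc(-c2coc3cc(OCCCSC(=S)N4CCN(Cc5ccccc5)CC4)ccc3c2=O)cc1` differs from compound 2 by phenyl in place of methyl on a saturated chain carbon bound to an amine nitrogen in a ring, or, cut one bond further out, ethyl to benzyl.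

Among the measured compounds shown here, only one measured step bears on this change: a 3.2-fold higher number from compound 1 to compound 2 (0.51 log units; beyond the scatter), a modest one, with methyl in place of hydrogen at that kind of carbon. That step points upward, but no phenyl group enters in it, so it is thin support. The expected 1.3-fold higher number from compound 2 to compound 3 (0.10 log units; within the scatter) is small, upward if anything, and not beyond the scatter in this assay. For compound 3 the estimated value is 9000 nM, with an expected range from 2500 nM to 30000 nM.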

Compound 3, half-maximal inhibitory concentration: 14900 nM
Estimate against measurement, compound 3: 1.7-fold (0.22 log units) below, and the stated range covers the measured number.
By their numbers in this assay, from the lowest: compound 1; then compound 2; then compound 3.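

In this assay the rise seen with methyl at this carbon continues with phenyl at the same place, the ethyl to benzyl change giving a further step (a 2.1-fold higher number from compound 2 to compound 3 (0.32 log units; beyond the scatter)). Taken from the hydrogen end of the series, the phenyl change gives the largest step shown (a 6.7-fold higher number from compound 1 to compound 3 (0.83 log units; beyond the scatter)), so all three compounds fall in one order, with no compound against it, and the ring-bearing group does not recover the number of compound 1. Nothing measured here explains this order.

Three compounds cannot show whether the rise depends on the aromatic ring or simply continues with any added carbon, and a straight propyl or butyl chain at this carbon would separate the two. As far as these compounds go, whether a hydroxyl, an amine or a carboxylic acid at this carbon would lower the number also remains open.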